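Changing the amide group of compound 2

The source may report more compounds than this note shows. Statements on the series, on what has been measured and on what is new or still open speak of the compounds shown alone.

In a functional assay on MCF7 cells (Homo sapiens) for cytotoxicity, read by sulforhodamine B assay, with a stated time of 72 h (a higher number here means a weaker inhibitor, a lower number a stronger inhibitor), compound 2 `Cc1ccc(-c2cc(C(=O)Nc3ccc(Cl)nc3Cl)nn2-c2ccc3ccccc3n2)cc1` gives 12700 nM, and compound 1 `Cc1ccc(-c2cc(C(=O)Nc3ccncc3)nn2-c2ccc3ccccc3n2)cc1` gives 15400 nM. With only these two numbers, compound 2 stands level with compound 1 and holds no real lead. Compound 3 `Cc1ccc(-c2cc(C(=O)Nc3ccnc(Cl)c3)nn2-c2ccc3ccccc3n2)cc1` shares their core and differs from compound 2 at one place, on the amide-type nitrogen, where 2-chloropyridin-4-yl takes the place of 2,6-dichloropyridin-3-yl: 2-chloropyridin-4-yl in place of 2,6-dichloropyridin-3-yl on an amide-type nitrogen. Within the data shown here, one measured step bears on this change, since it altered the group at the same place: a 1.2-fold lower number from compound 1 to compound 2 (0.08 log units; within the scatter). Among the measured compounds shown here, that single step is small, but it offers thin evidence, and no measured compound yet carries the entering group. No shift beyond the scatter is therefore expected in this assay, and the expected change is a 1.1-fold lower number from compound 2 to compound 3 (0.02 log units; within the scatter). The estimate for compound 3 is 12000 nM, with an expected range of 5000 nM to 28000 nM.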

Compound 3, half-maximal inhibitory concentration: 3300 nM
The estimate for compound 3 lay 3.6-fold (0.56 log units) above the measured number, and the stated range ends above it.
By their numbers in this assay, from the lowest: compound 3; then compounds 2 and 1 (each within the scatter of the next).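

In this assay the group on the amide-type nitrogen proves able to move the number: the earlier change at this place stayed within the scatter, whereas this one gives a 3.8-fold lower number from compound 2 to compound 3 (0.59 log units; beyond the scatter) with 2-chloropyridin-4-yl as the entering group. Compound 1 and compound 3 differ only by chloro in place of hydrogen on an aromatic carbon, and that single swap gives a 4.7-fold lower number from compound 1 to compound 3 (0.67 log units; beyond the scatter) in this series, so even one added chlorine can count here. Nothing measured here explains why the number falls.

The compounds shown leave open whether another group in that same place on the pyridin-4-yl ring, such as fluoro, methyl or methoxy, would do as well as chloro. They also leave open whether a second chloro on the 2-chloropyridin-4-yl group would lower the number further or raise it.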